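This account rests on a few compounds, and the source may have more. Where it says the series, first, only, none or still open, it means among the compounds named here.

Working notes on the aryl exchange at the triazole nitrogen.

Compound 1 `Oc1cc(C(F)(F)F)ccc1-c1nc(-c2ccccc2O)n(-c2ccc(I)cc2)n1` gives 94.4% in a functional assay on PC-12 cells (Rattus norvegicus) for cytotoxicity, read by MTT assay, with stated times of 2 h and 24 h, tested at 5 uM; a lower number here means a weaker effect, a higher number a stronger effect of the compound at the concentration tested. Compound 2 `Oc1cc(C(F)(F)F)ccc1-c1nc(-c2ccccc2O)n(-c2cccc(C(F)(F)F)c2)n1` gives 92.2% in this assay, and compound 3 `Oc1cc(C(F)(F)F)ccc1-c1nc(-c2ccccc2O)n(-c2ccc(Cl)cc2Cl)n1` gives 86.7% in this assay. Compound 1 carries the highest of the three numbers, but the gaps are small: a number 2.2 percentage points lower from compound 1 to compound 2 (within the scatter) and a number 7.7 percentage points lower from compound 1 to compound 3 (within the scatter), with a number 5.5 percentage points lower from compound 2 to compound 3 (within the scatter) between the other two, so the three compounds are not separated beyond the scatter.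

The next compound, compound 4 `Cc1cc(C)cc(-n2nc(-c3ccc(C(F)(F)F)cc3O)nc2-c2ccccc2O)c1`, differs from compound 1 only at the group on the aromatic nitrogen: 3,5-dimethylphenyl in place of 4-iodophenyl on an aromatic nitrogen.

Every step measured so far changes the same group on the same nitrogen, and each of them stayed within the scatter, whether the entering group carried a halogen or a trifluoromethyl. Going by the values given here, no step on another part of the shared core exists in this set. On that basis the exchange for 3,5-dimethylphenyl is expected to give no step beyond the scatter in this assay, and the estimated step is a number 3.4 percentage points lower from compound 1 to compound 4 (within the scatter). Compound 4 is therefore estimated at 91%, expected between 80% and 98%.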

Compound 4, a percentage reported as activity, at one concentration (the size of the read-out at that concentration, not a potency): 102%
Beside the measured number, compound 4's estimate is 11 percentage points below it; measured number above the stated range.
By their numbers in this assay, from the lowest: compounds 3, 2, 1 and 4 (each within the scatter of the next, the first and the last beyond it).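

Going by these compounds alone, the exchange gives the only step at this nitrogen that lies beyond the scatter in this assay: a number 15.3 percentage points higher from compound 3 to compound 4 (beyond the scatter). The other two steps, a number 7.6 percentage points higher from compound 1 to compound 4 (within the scatter) and a number 9.8 percentage points higher from compound 2 to compound 4 (within the scatter), do not separate compound 4 from compound 1 or compound 2, so the group on this nitrogen can shift the read-out, but here this is resolved only between 2,4-dichlorophenyl and 3,5-dimethylphenyl. Nothing available explains that separation.

Every compound shown carries a carbon-only aromatic ring on this nitrogen, so the effect of an aryl group bearing an amine or a carboxylic acid, or of a longer alkyl chain in place of the ring, remains open. Changes on the rest of the shared core also remain open, and a read-out at one concentration gives no potency.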